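Thiophenemethyl amides as TRPM8 agonists: pyrazolyl for isobutyl

The source may report more compounds than this note shows. Statements on the series, on what has been measured and on what is new or still open speak of the compounds shown alone.

Measured compounds:
- compound 1, `Cc1ccc(OCC(=O)N(Cc2cccs2)CC(C)C)cc1`: 900 nM
- compound 2, `CCN(Cc1cccs1)C(=O)c1cc2cc(C)ccc2[nH]1`: 2010 nM

Compound 1 gives the lower of the two numbers in an assay on HEK293 cells for agonist activity at transient receptor potential cation channel subfamily M member 8 (Homo sapiens), read by fluorescence and calcium flux, with a stated time of 15 min; on this read-out higher numbers stand for an effect only at larger amounts of compound and lower numbers for an effect already at smaller amounts; compound 2 gives 2010 nM in this assay, a gap beyond the usual scatter. Among the compounds with values here, the two share the thiophenemethyl amide but differ in several places, so no single step between them can be read.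

Compound 3, `Cc1ccc(OCC(=O)N(Cc2cccs2)c2cn[nH]c2)cc1`, keeps the core of compound 1 and changes one place: 1H-pyrazol-4-yl in place of isobutyl on an amide-type nitrogen. Within the data shown here, no measured pair shows what such a change does, so the expectation rests on compound 1 alone. Replacing a saturated chain by an aromatic ring bearing a donor and an acceptor is a sizeable change at the amide-type nitrogen, and a step of moderate size towards a higher number is expected, a 2.8-fold higher number from compound 1 to compound 3 (0.44 log units; beyond the scatter), though a result within the scatter is possible. Compound 3 is expected to give 2500 nM in this assay, with a range from 700 nM to 9000 nM.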

Compound 3, half-maximal effective concentration: 1.4 nM
Estimate against measurement, compound 3: 1800-fold (3.25 log units) above; measured number outside the range, below it.
By their numbers in this assay, from the lowest: compound 3; then compound 1; then compound 2.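

In this assay, within the data shown here, 1H-pyrazol-4-yl in place of isobutyl on the amide-type nitrogen gives a 640-fold lower number from compound 1 to compound 3 (2.81 log units; beyond the scatter), the first step that can be read and a large one. The read-out thus responds strongly to the group at this position, and a saturated chain is not required there: an aromatic ring with a hydrogen-bond donor and a hydrogen-bond acceptor takes its place with a large gain on this read-out. Nothing at hand accounts for the size of this step.

On these data alone, whether the step comes from the ring itself, its donor or its acceptor stays open; phenyl or 1-methyl-1H-pyrazol-4-yl on the same nitrogen would begin to separate these. Also open, as far as these compounds go, is whether the same exchange gives a step of this size on the core of compound 2.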